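This account rests on a few compounds, and the source may have more. Where it says the series, first, only, none or still open, it means among the compounds named here.

Measured so far in a functional assay on DLD-1 cells (Homo sapiens) for antiproliferative activity, read by CellTiter-Glo, with a stated time of 72 h; a lower number here means a stronger inhibitor, a higher number a weaker inhibitor:

compound 1, `Cc1cc(C)c(S(=O)(=O)N2CCC(N3CCC(CCO)CC3)CC2)c(C)c1`, 19 nM
compound 2, `Cc1cc(C)c(S(=O)(=O)N2CCC(N3CCC(O)CC3)CC2)c(C)c1`, 106 nM

Compound 2 has the higher of these two numbers in this assay; the step of a 5.6-fold higher number from compound 1 to compound 2 (0.75 log units; beyond the scatter) separates it from compound 1. Compound 3, `Cc1cc(C)c(S(=O)(=O)N2CCC(N3CCCCC3)CC2)c(C)c1`, differs from compound 2 by hydrogen in place of hydroxy on a saturated ring carbon. Among the compounds with values here, no measured step covers this exact change; the only step available, a 5.6-fold higher number from compound 1 to compound 2 (0.75 log units; beyond the scatter), shows that shortening the hydroxyl-bearing group weakened inhibition, so removing the hydroxy altogether is expected to weaken it again, though only modestly and with wide uncertainty. Compound 3 is therefore estimated at 200 nM, within 60 nM to 700 nM, a step of a 1.9-fold higher number from compound 2 to compound 3 (0.28 log units; within the scatter) in this assay.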

Compound 3, half-maximal inhibitory concentration: 2200 nM
Compound 3: middle estimate off by 11-fold (1.04 log units), on the low side, outside the stated range (above it).
By their numbers in this assay, from the lowest: compound 1; then compound 2; then compound 3.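

Taking away the hydroxy, so that 4-hydroxypiperidin-1-yl becomes piperidin-1-yl, weakens inhibition in this assay far more than shortening the side group did, with a 21-fold higher number from compound 2 to compound 3 (1.32 log units; beyond the scatter) against a 5.6-fold higher number from compound 1 to compound 2 (0.75 log units; beyond the scatter). Losing the whole 2-hydroxyethyl group gives a 120-fold higher number from compound 1 to compound 3 (2.06 log units; beyond the scatter), so having a hydroxy on this ring carbon matters more here than how far it extends. No available evidence explains this sensitivity. Still open, as far as these compounds go, is whether the hydroxy itself is required, or whether an amine, a carboxylic acid or a longer chain such as 3-hydroxypropyl would serve at this ring carbon.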